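Compound 3 against the assay limit of compound 1

The source may hold more compounds than are shown below. What is called first, only, known or untested is meant among the compounds shown, and "the series" means these compounds.

- compound 1 `COc1cc(-c2nn(-c3cccc(NC(=O)c4cccc(C(F)(F)F)c4)c3)cc2-c2ccncc2)ccc1Cl`: > 50000 nM
- compound 2 `O=C(Nc1cccc(-n2cc(-c3ccncc3)c(-c3ccc(Cl)c(O)c3)n2)c1)Nc1ccc(Cl)c(Cl)c1`: 26300 nM

In a functional assay on KM12 cells (Homo sapiens) for inhibition, read by sulforhodamine B assay, with a stated time of 48 h (on this read-out higher numbers stand for lower toxicity in this test and lower numbers for higher toxicity in this test), compound 1 gives > 50000 nM, which is a limit of the assay and not a number. On these data alone, that places compound 1 at the limit of > 50000 nM in this assay, at which 1 of the 2 values shown sits, so its true position is unknown. Among the measured compounds shown here, compound 2 is the only measured compound with a number, at 26300 nM.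

Compound 3 `COc1cc(-c2nn(-c3cccc(NC(=O)Nc4ccc(Cl)c(C(F)(F)F)c4)c3)cc2-c2ccncc2)ccc1Cl` is not yet measured. It differs from compound 1 by (4-chloro-3-(trifluoromethyl)phenyl)amino in place of 3-(trifluoromethyl)phenyl on a carbonyl carbon, with (4-chloro-3-(trifluoromethyl)phenyl)amino in place of 3-(trifluoromethyl)phenyl on a carbonyl carbon. For the measured compounds named here, no measured step covers this change, so the expectation leans on compound 2 at 26300 nM. The expected shift is modest and toward lower numbers in this assay, estimated as an at least 1.6-fold lower number from compound 1 to compound 3 (0.22 log units; that floor lies within the scatter). For compound 3 the estimated value is 30000 nM, with an expected range of 12000 nM to 50000 nM.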

Compound 3, concentration lethal to 50% of the cells: 14900 nM
Compound 3: the middle estimate sits 2.0-fold (0.30 log units) above what was measured, within the range that was stated.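

In this assay, (4-chloro-3-(trifluoromethyl)phenyl)amino in place of 3-(trifluoromethyl)phenyl, on a carbonyl carbon whose other neighbours are amide-type nitrogen, gives an at least 3.3-fold lower number from compound 1 to compound 3 (0.52 log units; beyond the scatter). Among the compounds shown here, this is the first readable step at this position, and it shows that this one change on the core of compound 1 is enough to bring the read-out to a number, with compound 3 at 14900 nM. The step is only a floor because the entry for compound 1 is a limit of the assay and not a number: the limit of > 50000 nM in this assay, at which 1 of the 3 values shown sits.

The chlorine and the nitrogen enter together, so the compounds shown do not separate their contributions to the step. Also open, on these data alone, is how a piperidine amide or a longer alkyl chain on the same carbonyl carbon would read in this assay.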